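This account rests on a few compounds, and the source may have more. Where it says the series, first, only, none or still open, it means among the compounds named here.

Measured in a functional assay on A549 cells (Homo sapiens) for cytotoxicity, read by MTT assay, with a stated time of 48 h (a higher number here means a weaker inhibitor, a lower number a stronger inhibitor), so far:
Compound 1 `C=C(c1ccc(OC)cc1)c1cc(OC)c(OC)c(OC)c1-c1ccccc1` gives 22000 nM here
Compound 2 `C=C(c1ccc(Cl)cc1)c1cc(OC)c(OC)c(OC)c1-c1ccccc1` gives 40000 nM here

Among the measured compounds shown here, compound 2 stands within the scatter of compound 1, the only other measured compound, and the pair shows a 1.8-fold higher number from compound 1 to compound 2 (0.26 log units; within the scatter) with chloro in place of methoxy on an aromatic carbon. The next compound is compound 3 `C=C(c1ccc(C(F)(F)F)cc1)c1cc(OC)c(OC)c(OC)c1-c1ccccc1`, which has trifluoromethyl in place of chloro on an aromatic carbon, para to a large group trifluoromethyl in place of chloro on an aromatic carbon in an otherwise unchanged structure. For the measured compounds named here, only that one measured step bears on this change, and it involves a different incoming group, so it offers limited guidance. Going by the values given here, no trifluoromethyl compound has been measured. No step beyond the scatter is therefore expected in this assay in either direction. The estimate means a 1.1-fold lower number from compound 2 to compound 3 (0.06 log units; within the scatter) as the expected outcome. For compound 3 the estimated value is 35000 nM with an expected range from 15000 nM to 80000 nM in this cell assay.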

Compound 3, half-maximal inhibitory concentration: 48000 nM
The estimate for compound 3 lay 1.4-fold (0.14 log units) below the measured number; the measured number falls inside the stated range.
By their numbers in this assay, from the lowest: compounds 1, 2 and 3 (each within the scatter of the next, the first and the last beyond it).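

In this assay, trifluoromethyl in place of chloro gives a 1.2-fold higher number from compound 2 to compound 3 (0.08 log units; within the scatter), so at this position of the 4-chlorophenyl group, four heavy atoms can stand in place of one with no change that can be told from the scatter. Set against the methoxy group, however, trifluoromethyl gives a 2.2-fold higher number from compound 1 to compound 3 (0.34 log units; beyond the scatter), the first step here to clear the scatter, though only modestly. Nothing measured here accounts for either step.

The compounds shown leave open whether an amine, a hydroxyl or a carboxylic acid at this position would move the number in either direction. They also leave open whether replacing the methoxy groups on the shared core would matter more than any change on this aromatic ring.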